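Neopentyl to isobutyl: the step to compound 4

The compounds below may be only part of what the source reports. "The series", "measured", "known", "first", "only" and "open" are said of these compounds alone.

In a functional assay (strain AB) with Danio rerio as the target, read by microscopy, with a stated time of 1 h (on this read-out higher numbers stand for an effect only at larger amounts of compound and lower numbers for an effect already at smaller amounts), compound 3 `CC(C)(C)C[N+]1(C)CCc2c(sc(NC(=O)Nc3ccc(Cl)cc3)c2C(N)=O)C1` gives 290 nM. Compound 1 `CC(C)(C)OC(=O)CCC[N+]1(C)CCc2c(sc(NC(=O)Nc3ccc(Cl)cc3)c2C(N)=O)C1` gives 250 nM, and compound 2 `C[N+]1(CC2CCC2)CCc2c(sc(NC(=O)Nc3ccc(Cl)cc3)c2C(N)=O)C1` gives 210 nM. Compound 3 therefore stands within the scatter of both.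

Compound 4 `CC(C)C[N+]1(C)CCc2c(sc(NC(=O)Nc3ccc(Cl)cc3)c2C(N)=O)C1` has hydrogen in place of methyl on a saturated chain carbon bound to three saturated chain carbons, so neopentyl becomes isobutyl: hydrogen in place of methyl on a saturated chain carbon bound to three saturated chain carbons.

Among the compounds with values here, three measured steps bear on this change: a 1.2-fold lower number from compound 1 to compound 2 (0.08 log units; within the scatter), a 1.2-fold higher number from compound 1 to compound 3 (0.06 log units; within the scatter) and a 1.4-fold higher number from compound 2 to compound 3 (0.14 log units; within the scatter). Each exchanges a group on a saturated chain carbon bound to an amine nitrogen in a ring, and all three stay within the scatter. None of them removes a single methyl, so the support is indirect. On these steps, no change beyond the scatter is expected in this assay.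

The estimated step is a 1.1-fold lower number from compound 3 to compound 4 (0.05 log units; within the scatter).

For compound 4 the expected value is 260 nM, with an estimated range of 140 nM to 480 nM.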

Compound 4, half-maximal effective concentration: 380 nM
The estimate for compound 4 lay 1.5-fold (0.16 log units) below the measured number; measured number inside the range.
By their numbers in this assay, from the lowest: compounds 2, 1, 3 and 4 (each within the scatter of the next).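

In this assay, within the data shown here, hydrogen in place of methyl on a saturated chain carbon bound to three saturated chain carbons is the first direct test of this change (a 1.3-fold higher number from compound 3 to compound 4 (0.12 log units; within the scatter)), and the step stays within the scatter. Isopropyl in place of cyclobutyl (a 1.8-fold higher number from compound 2 to compound 4 (0.26 log units; within the scatter)) and in place of 2-(tert-butoxycarbonyl)ethyl (a 1.5-fold higher number from compound 1 to compound 4 (0.18 log units; within the scatter)) also stay within it, so all four compounds form one group with no separation among them. No measured evidence bears on these numbers or gives a cause for them.

Open, as far as these compounds go, is whether a carboxylic acid or a primary amine at the end of this chain, in place of the tert-butyl ester, would step outside the scatter. Also open, from the compounds shown here alone, is whether a plain ethyl or a longer unbranched chain on the amine nitrogen in a ring would do so.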